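Thiourea-linked quinazoline sulfonamides: aniline swap on compound 2

The source may hold more compounds than are shown below. What is called first, only, known or untested is meant among the compounds shown, and "the series" means these compounds.

Measured so far:
- compound 1 `COc1cc2ncnc(Nc3cccc(C)c3)c2cc1OCCCCC(=O)Nc1ccc(S(N)(=O)=O)cc1`: 32100 nM
- compound 2 `NS(=O)(=O)c1ccc(NC(=S)Nc2ccc3ncnc(Nc4ccc(Cl)c(C(F)(F)F)c4)c3c2)cc1`: 11800 nM

In a functional assay on NCI-H1975 cells (Homo sapiens) for antiproliferative activity, read by MTT assay, with a stated time of 72 h (a lower number here means a stronger inhibitor, a higher number a weaker inhibitor), compound 2 gives 11800 nM and compound 1 gives 32100 nM; compound 2 holds the lower of the two numbers, and the gap to compound 1 lies beyond the scatter. Within the data shown here, the two share the sulfonamide-bearing aryl end but differ in linker and in the aniline, so no single step connects them.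

Compound 3 `Cc1cccc(Nc2ncnc3ccc(NC(=S)Nc4ccc(S(N)(=O)=O)cc4)cc23)c1` keeps the thiourea linker of compound 2 and changes only the aniline: 3-methylphenyl in place of 4-chloro-3-(trifluoromethyl)phenyl on a nitrogen on an aromatic ring. This is the aniline already present in compound 1, where it sits with a different linker, so its weight cannot be separated from the linker change there. Among the measured compounds shown here, with no matched pair to lean on, the step is expected to be modest and, if anything, toward a higher number.

For compound 3 the estimate in this assay is 16000 nM (range 5000 nM to 50000 nM), which means an expected step of a 1.4-fold higher number from compound 2 to compound 3 (0.13 log units; within the scatter).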

Compound 3, half-maximal inhibitory concentration: 35400 nM
The estimate for compound 3 lay 2.2-fold (0.34 log units) below the measured number, and the stated range covers the measured number.
By their numbers in this assay, from the lowest: compound 2; then compounds 1 and 3 (each within the scatter of the next).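

With the thiourea linker held fixed, the aniline position is not neutral in this assay: 3-methylphenyl in place of 4-chloro-3-(trifluoromethyl)phenyl on a nitrogen on an aromatic ring gives a 3.0-fold higher number from compound 2 to compound 3 (0.48 log units; beyond the scatter) and lies beyond the scatter. Among these compounds, this is the first step that isolates the aniline, since compound 1 and compound 2 differ in more than one place. No supporting measurement bears on why the number moves.

From the compounds shown here alone, the step swaps the whole aryl group, so the separate shares of the chlorine and the trifluoromethyl group stay open, as does the share of the methyl group. Also open, going by these compounds, is how a nitrile or an ethynyl group on this aniline would read with the thiourea linker.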